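The compounds below may be only part of what the source reports. "The series", "measured", "known", "first", "only" and "open" are said of these compounds alone.

Of the compounds shown here, two built on a shared core have numbers so far in a functional assay on Jurkat cells (Homo sapiens) for inhibition, read by CCK-8 assay, with a stated time of 48 h; a lower number here means a stronger inhibitor of growth, a higher number a weaker inhibitor of growth. Compound 1 (`CN1CCN(c2ccc(Nc3ncc(Cl)c(NCc4ccc(C(F)(F)F)cc4)n3)nc2)CC1`) gives 7960 nM, and compound 2 (`Cc1ccc(Nc2nc(Nc3ccc(N4CCN(C)CC4)cn3)ncc2Cl)cc1`) gives 30900 nM. Compound 2 therefore holds the higher of the two numbers and is the weaker growth inhibitor of the pair.

Compound 3 (`CCc1ccc(Nc2nc(Nc3ccc(N4CCN(C)CC4)cn3)ncc2Cl)cc1`) differs from compound 2 by one small edit: methyl in place of hydrogen on a saturated chain carbon bound to an aromatic carbon. Methyl in place of hydrogen on a saturated chain carbon bound to an aromatic carbon turns 4-methylphenyl into 4-ethylphenyl.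

For the measured compounds named here, only one measured step bears on this edit, and only loosely. That step is a 3.9-fold higher number from compound 1 to compound 2 (0.59 log units; beyond the scatter), and it came with 4-methylphenyl in place of 4-(trifluoromethyl)benzyl, a swap of the whole group rather than the addition of one methyl. Going by the values given here, no measured pair tests the new edit directly, so a smaller step than that one is expected, leaning slightly towards a lower number. The expected change is a 1.4-fold lower number from compound 2 to compound 3 (0.15 log units; within the scatter), which may not stand clear of the scatter. For compound 3 the estimated value in this assay is 22000 nM, with an expected range from 9000 nM to 50000 nM.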

Compound 3, concentration for 50% growth inhibition: 11100 nM
Compound 3: middle estimate off by 2.0-fold (0.30 log units), on the high side; measured number inside the range.
By their numbers in this assay, from the lowest: compounds 1 and 3 (each within the scatter of the next); then compound 2.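

In this assay, one added methyl on a saturated chain carbon bound to an aromatic carbon, which turns 4-methylphenyl into 4-ethylphenyl, gives a 2.8-fold lower number from compound 2 to compound 3 (0.44 log units; beyond the scatter), so even an edit of one heavy atom at this position can move the number past the usual scatter. The 4-ethylphenyl group also brings this series level with the 4-(trifluoromethyl)benzyl group: the comparison gives a 1.4-fold higher number from compound 1 to compound 3 (0.14 log units; within the scatter), and that difference is too small for either of these two groups to be ranked above the other in this assay. The results show the size of these differences, but no measurement here accounts for them.

Methyl and ethyl are only two chain lengths, so they cannot show whether a longer chain, such as propyl or butyl, would lower the number further, leave it level or raise it again. Also open, going by these compounds, is how this position would respond to a chain ending in an amine or a carboxylic acid, which would test more than chain length alone.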